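The source may report more compounds than this note shows. Statements on the series, on what has been measured and on what is new or still open speak of the compounds shown alone.

Compound 3, with the structure `NC(=O)c1c(NC(=O)c2ccccc2)sc2c1CCN(C(=S)Nc1ccccc1Cl)C2`, gives in a functional assay on HeLa cells (Homo sapiens) for antiproliferative activity, with a stated time of 24 h (on this read-out higher numbers stand for weaker inhibition and lower numbers for stronger inhibition), only a limit of the assay, > 50000 nM, and no number. Compound 2, `NC(=O)c1c(NC(=O)c2ccccc2Cl)sc2c1CCN(C(=S)Nc1ccc(C(F)(F)F)cc1)C2`, likewise returns only a limit in this assay, > 50000 nM. Of the three measured compounds only compound 1, `NC(=O)c1c(NC(=O)c2ccccc2Cl)sc2c1CCN(Cc1ccc(Cl)cc1Cl)C2`, yields a number in this assay, 21100 nM; the other two sit at the limit of > 50000 nM in this assay, at which 2 of the 3 values shown sit. Compound 4, `NC(=O)c1c(NC(=O)c2ccccc2C(F)(F)F)sc2c1CCN(C(=S)Nc1ccccc1Cl)C2`, differs from compound 3 by trifluoromethyl in place of hydrogen on an aromatic carbon. Going by the values given here, because compound 3 shows only > 50000 nM, no measured step can anchor the change, and the expected step from compound 3 to compound 4 is a step that the limit leaves unreadable from compound 3 to compound 4, none beyond the scatter. Compound 4 is therefore estimated at 60000 nM, within 15000 nM to 250000 nM, most likely again reported only as a limit.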

Compound 4, half-maximal inhibitory concentration: 46900 nM
Compound 4: middle estimate off by 1.3-fold (0.11 log units), on the high side; the range from low to high includes it.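

With 2-(trifluoromethyl)phenyl in place of phenyl, compound 4 gives a readable number in this assay, whereas compound 3 gives only a limit. The step is an at least 1.0-fold lower number from compound 3 to compound 4 (0.02 log units; that floor lies within the scatter), so trifluoromethyl is accepted on this aromatic carbon, but no gain beyond the scatter is shown. Two compounds remain without a number: the limit of > 50000 nM in this assay, at which 2 of the 4 values shown sit.

The true size of the step stays unread, as the limit leaves it open at its upper end. Also open, on these data alone, is how an amine or a carboxylic acid on this aromatic carbon would compare with trifluoromethyl.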